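The compounds below may be only part of what the source reports. "The series", "measured", "known", "first", "only" and "open" are said of these compounds alone.

Three compounds share one core and differ only in the group carried on an amine nitrogen in a ring. Compound 1 `CCC(C(=O)N1CCN(c2cccc(F)c2)CC1)N1C(=O)CCC1=O`, compound 2 `CCC(C(=O)N1CCN(c2ccccc2F)CC1)N1C(=O)CCC1=O` and compound 3 `CCC(C(=O)N1CCN(c2cccc(C)c2)CC1)N1C(=O)CCC1=O` were each tested in a functional assay on the whole organism (strain Swiss) with Mus musculus as the target, in the maximal electroshock model, with a stated time of 0.5 h, at a dose of 100 mg/kg by the intraperitoneal route; on this read-out higher numbers stand for a stronger effect at the one dose given and lower numbers for a weaker effect. In this assay compound 1 gives 0%, compound 2 gives 0% and compound 3 gives 0%. The steps of no change at the digits printed from compound 1 to compound 2 (within the scatter), no change at the digits printed from compound 1 to compound 3 (within the scatter) and no change at the digits printed from compound 2 to compound 3 (within the scatter) show that none of these changes moved the read-out beyond the scatter, so compound 3 stands level with compounds 1 and 2. Compound 4 `CCC(C(=O)N1CCN(c2cccc(Cl)c2)CC1)N1C(=O)CCC1=O` carries the change (chloro in place of methyl on an aromatic carbon). Since every measured step that altered the group on that amine nitrogen stayed within the scatter, compound 4 is expected to show a step of no change at the digits printed from compound 3 to compound 4 (within the scatter), no change beyond the scatter, with an estimated value of 0% between 0% and 10%.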

Compound 4, a percentage reported as activity, at one dose (the size of the read-out at that dose, not a potency): 50%
For compound 4 the middle estimate is 50 percentage points below the measured one, outside the stated range (above it).
By their numbers in this assay, from the lowest: compounds 1, 2 and 3 (each within the scatter of the next); then compound 4.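

this assay shows that the group on this aromatic carbon can matter: chloro in place of methyl gives a number 50 percentage points higher from compound 3 to compound 4 (beyond the scatter), and chloro in place of fluoro gives a number 50 percentage points higher from compound 1 to compound 4 (beyond the scatter). The change to 3-chlorophenyl from 2-fluorophenyl gives a number 50 percentage points higher from compound 2 to compound 4 (beyond the scatter), so swapping a single heavy atom can separate a compound from neighbours that looked level. Nothing available explains why chloro stands apart here. As far as these compounds go, whether a bromo or methoxy group at this place would behave like chloro stays open, as does how the effect changes with dose.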